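A few compounds are considered here, and "the series" means these few. Any claim that something is new, unique, unknown or untested is made for them only; others in the source may bear on it.

Three thiourea compounds have been tested so far, among them compound 1 `CC(C)[C@H](NC(=S)Nc1cc(C(F)(F)F)cc(C(F)(F)F)c1)c1nc2ccccc2[nH]1`, compound 2 `C[C@H](NC(=S)Nc1cc(C(F)(F)F)cc(C(F)(F)F)c1)c1nc2ccccc2[nH]1` and compound 3 `CC(C)C[C@H](NC(=S)Nc1ccccc1)c1nc2ccccc2[nH]1`. In a functional assay on HeLa cells (Homo sapiens) for cytotoxicity, read by MTT assay (a higher number here means a weaker inhibitor, a lower number a stronger inhibitor), compound 1 gives 28900 nM, and in this assay compound 3 gives 29100 nM, a number within the scatter of compound 1, so the two cannot be told apart. In this assay, for the measured compounds named here, compound 2 gives 133000 nM; the step of a 4.6-fold higher number from compound 1 to compound 2 (0.66 log units; beyond the scatter) shows that this compound stands beyond the scatter from compound 1, which is the only measured step here, and it concerns methyl in place of isopropyl.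

Compound 4 `CC(C)[C@@H](NC(=S)Nc1cc(C(F)(F)F)cc(C(F)(F)F)c1)c1nc2ccccc2[nH]1` is now considered. It differs from compound 1 in this way: the two compounds have the same atoms and bonds and differ only in configuration as drawn: 1 of 1 stereo elements differ; a stereocentre at a saturated chain carbon is drawn S in compound 1 and R in compound 4. No measured step concerns an inversion of configuration, so the step from compound 1 to compound 2 does not bear on this change, and nothing in the numbers shown says how this assay responds to the mirror arrangement. The expectation for compound 4 is therefore a change of no more than modest size, a 1.3-fold higher number from compound 1 to compound 4 (0.12 log units; within the scatter), leaning slightly toward a higher number. Compound 4 is estimated at 38000 nM, with a range from 10000 nM to 130000 nM.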

Compound 4, half-maximal inhibitory concentration: 16200 nM
Beside the measured number, compound 4's estimate is 2.3-fold (0.37 log units) above it; measured number inside the range.
By their numbers in this assay, from the lowest: compounds 4, 1 and 3 (each within the scatter of the next); then compound 2.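

At the saturated chain carbon that carries the isopropyl group, inverting the stereocentre from S to R gives a 1.8-fold lower number from compound 1 to compound 4 (0.25 log units; within the scatter) in this assay, so the two mirror arrangements cannot be told apart in this measurement. The earlier compounds shown here showed only that this carbon responds to a change of substituent, with a 4.6-fold higher number from compound 1 to compound 2 (0.66 log units; beyond the scatter), whereas the change of configuration at the same carbon stays within the scatter. The comparison isolates configuration, as nothing else separates the pair: the fact that compounds 1 and 4 differ only in the configuration as drawn

From the compounds shown here alone, whether the same holds for the mirror form of compound 2, with methyl on this carbon, stays open. So does how this assay would respond to a longer chain or a cyclohexyl group at this carbon, or to a carboxylic acid in place of a trifluoromethyl group.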